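Replacing the Aryl Group with Piperidine on a Shared Core

The source may report more compounds than this note shows. Statements on the series, on what has been measured and on what is new or still open speak of the compounds shown alone.

Of the compounds shown here, three built on one shared core have been tested in a functional assay on cells for antagonist activity at prostaglandin E2 receptor EP1 subtype (Rattus norvegicus), read by fluorescence and calcium flux, with a stated time of 60 s; on this read-out lower numbers stand for stronger inhibition and higher numbers for weaker inhibition. Compound 1 `O=C(O)c1cccc(Cc2c(-c3ccccc3)nn3ccccc23)n1` gives 2300 nM. Compound 2 `COc1ccc(-c2nn3cc(Cl)ccc3c2Cc2cccc(C(=O)O)n2)cc1` gives 5400 nM, the highest of the three numbers and therefore the weakest inhibition measured so far. Compound 3 `O=C(O)c1cccc(Cc2c(-c3ccoc3)nn3cc(Cl)ccc23)n1` gives 130 nM. For the measured compounds named here, the only comparison that alters a single place is a 42-fold lower number from compound 2 to compound 3 (1.62 log units; beyond the scatter), a large step and the single clue to how this position responds to a new group.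

Compound 4 `O=C(O)c1cccc(Cc2c(N3CCCCC3)nn3cc(Cl)ccc23)n1` has not yet been measured. It differs from compound 2 as piperidin-1-yl in place of 4-methoxyphenyl on an aromatic carbon. The altered place is the one that the earlier large step also changed, but the incoming piperidin-1-yl is a saturated ring rather than an aromatic one, so that step bears only loosely on it. Going by the values given here, no other measured step touches this change. A lower number is therefore expected for compound 4, most likely a moderate rather than a large step, with wide uncertainty. Compound 4 is expected to give 1500 nM, within 300 nM to 6000 nM. The expected change is a 3.6-fold lower number from compound 2 to compound 4 (0.56 log units; beyond the scatter).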

Compound 4, half-maximal inhibitory concentration: 79 nM
The estimate for compound 4 lay 19-fold (1.28 log units) above the measured number; measured number outside the range, below it.
By their numbers in this assay, from the lowest: compounds 4 and 3 (each within the scatter of the next); then compound 1; then compound 2.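

The position does not need an aromatic ring: the saturated piperidin-1-yl group replacing 4-methoxyphenyl gives a 68-fold lower number from compound 2 to compound 4 (1.83 log units; beyond the scatter) and is a large step, just as the furan-3-yl change gave a 42-fold lower number from compound 2 to compound 3 (1.62 log units; beyond the scatter). Exchanging furan-3-yl for piperidin-1-yl gives a 1.6-fold lower number from compound 3 to compound 4 (0.22 log units; within the scatter) and so does not separate these two groups, which leaves 4-methoxyphenyl as the one that stands apart among the three groups compared at this place. No measurement at hand explains why two such different rings give matching results here.

On these data alone, it remains open whether a ring is needed at all, which a diethylamino group could test, and whether morpholine, with an oxygen in the ring, would match piperidin-1-yl. Compound 1 differs from these compounds in more than one place, so the effect of its plain phenyl group also remains unresolved.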